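Swapping furan-2-yl for thiophen-3-yl at the assay limit

A few compounds are considered here, and "the series" means these few. Any claim that something is new, unique, unknown or untested is made for them only; others in the source may bear on it.

In a functional assay on HeLa S3 cells (Homo sapiens) for antiproliferative activity, read by XTT assay, with a stated time of 72 h (a higher number here means a weaker inhibitor, a lower number a stronger inhibitor), each value so far is a limit of the assay:
- Compound 1 `CNc1ncnc2c1c(-c1cc3ccccc3o1)cn2[C@@H]1O[C@H](CO)[C@@H](O)[C@H]1O` gives > 20000 nM as a limit
- Compound 2 `Cc1ncnc2c1c(-c1ccoc1)cn2[C@@H]1O[C@H](CO)[C@@H](O)[C@H]1O` gives > 20000 nM as a limit
- Compound 3 `Nc1nc(N)c2c(-c3ccco3)cn([C@@H]3O[C@H](CO)[C@@H](O)[C@H]3O)c2n1` gives > 20000 nM as a limit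

Compound 3 has no exact number of its own, and it stands with the other two compounds: the limit of > 20000 nM in this assay, at which 3 of the 3 values shown sit, applies to all of them.

Within the data shown here, compound 4 `Nc1nc(N)c2c(-c3ccsc3)cn([C@@H]3O[C@H](CO)[C@@H](O)[C@H]3O)c2n1` carries thiophen-3-yl in place of furan-2-yl on an aromatic carbon as its only change. Among the measured compounds shown here, no measured pair shows what such a swap does. In this assay no change beyond the usual scatter is expected, and the estimated step is a number no higher from compound 3 to compound 4 (the limit leaves the size open) with no firm direction. For compound 4 the estimated value is 20000 nM within an expected range of 7000 nM to 40000 nM and it may again prove only a limit.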

Compound 4, half-maximal inhibitory concentration: > 20000 nM
Compound 4: a limit, no number; the forecaster's own chance of this, stated with the estimate: 80%; the middle value sits exactly at the limit.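

Compound 3 and compound 4 both remain at the assay limit, so swapping furan-2-yl for thiophen-3-yl gives no readable step: the limit of > 20000 nM in this assay, at which 4 of the 4 values shown sit.

The compounds shown leave open what change, if any, would produce an exact value.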